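Three Pyrrolinone Hydroxamates and a Fourth Awaiting Its Number

The compounds below may be only part of what the source reports. "The series", "measured", "known", "first", "only" and "open" are said of these compounds alone.

The series shares one core, carried in compound 1 `Cc1ccccc1CN1CC=C(CCC(=O)NO)C1=O`, compound 2 `CC(C)(C)c1ccc(CCCN2CC=C(CCC(=O)NO)C2=O)cc1` and compound 3 `O=C(CCC1=CCN(Cc2ccc(F)cc2)C1=O)NO`, and differs only in the group hung on the ring nitrogen. In a functional assay on PC-3 cells (Homo sapiens) for inhibition, read by sulforhodamine B assay (a higher number here means a weaker inhibitor of growth, a lower number a stronger inhibitor of growth), compound 1 gives 4620 nM, and compound 2 gives 3480 nM. Compound 3 gives 5310 nM in this assay. Its number stands at the high end of the three, yet the gap to compound 1 and the gap to compound 2 both lie within the usual scatter, so the three compounds cannot be told apart on these measurements.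

Compound 4 `CC(C)(C)c1ccc(CN2CC=C(CCC(=O)NO)C2=O)cc1` has not yet been measured. It differs from compound 3 in one place: tert-butyl in place of fluoro on an aromatic carbon. For the measured compounds named here, the benzyl-linked ring now carries the same tert-butyl group that compound 2 carries on its longer chain, though with no step between measured compounds to rest on, any expectation stays loose. Since compound 2 shows 3480 nM, a number close to compound 3, the change is expected to bring a step no larger than the scatter, if anything toward a slightly lower value. The expected step is a 1.3-fold lower number from compound 3 to compound 4 (0.12 log units; within the scatter). For compound 4 the estimate in this assay is 4000 nM, within 1800 nM to 9000 nM.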

Compound 4, concentration for 50% growth inhibition: 1830 nM
Compound 4: the middle estimate sits 2.2-fold (0.34 log units) above what was measured; measured number inside the range.
By their numbers in this assay, from the lowest: compounds 4, 2, 1 and 3 (each within the scatter of the next, the first and the last beyond it).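

In this assay, for the compounds shown here, the exchange of fluoro for tert-butyl on an aromatic carbon, para to a large group, gives a 2.9-fold lower number from compound 3 to compound 4 (0.46 log units; beyond the scatter) and this is the first single-place step, modest in size but beyond the scatter. Going by these compounds alone, the three earlier compounds lay within the scatter of one another and offered no such step, so they could not show that the number responds to a change at this carbon. The result ties that response to this one exchange, from a group of 1 heavy atom to a group of 4 heavy atoms, and to no wider trend. Nothing available explains the step.

With only fluoro and tert-butyl shown at this carbon, it remains open whether the step follows the count of heavy atoms or belongs to tert-butyl itself, and how an amine, a carboxylic acid or a methoxy group would read there. Compound 2 at 3480 nM and compound 4 at 1830 nM lie within the scatter of each other, so the effect of the longer chain linking the tert-butyl-bearing ring to the ring nitrogen also stays unresolved.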